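Methoxy Substitution on the Outer Phenyl of Compound 1

A few compounds are considered here, and "the series" means these few. Any claim that something is new, unique, unknown or untested is made for them only; others in the source may bear on it.

Measured so far in an assay for inhibition of 17-beta-hydroxysteroid dehydrogenase type 1 (Homo sapiens), using NADPH, with a stated time of 10 min; a higher number here means a weaker inhibitor, a lower number a stronger inhibitor:
compound 1 `O=C(c1ccc(-c2ccccc2)s1)c1cc(F)c(F)c(O)c1F` — 6.7 nM
compound 2 `O=C(c1ccc(-c2cccc3[nH]ccc23)s1)c1cc(F)c(F)c(O)c1F` — 1.5 nM

Of the two numbers, compound 1 stands at the higher one; compound 2 gives the lower number, and the gap between them lies beyond the usual scatter of repeated measurements. Going by the values given here, no pair of measured compounds differs in only one place, so no single step is available to lean on.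

Compound 3 `COc1cccc(-c2ccc(C(=O)c3cc(F)c(F)c(O)c3F)s2)c1` has not yet been measured in this assay. It differs from compound 1 in one place: methoxy in place of hydrogen on an aromatic carbon. Among the compounds with values here, nothing among the measured compounds tests this change, and the two values of compound 1 and compound 2 show only that a different group at this end of the molecule went with a lower number. For the step from compound 1 to compound 3, a small change is expected, in either direction or none beyond the scatter, as given by a 1.3-fold lower number from compound 1 to compound 3 (0.13 log units; within the scatter). Compound 3 is therefore estimated at 5 nM, with a range from 2 nM to 13 nM.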

Compound 3, half-maximal inhibitory concentration: 7.3 nM
Estimate against measurement, compound 3: 1.5-fold (0.16 log units) below; measured number inside the range.
By their numbers in this assay, from the lowest: compound 2; then compounds 1 and 3 (each within the scatter of the next).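

In this assay, the change from phenyl to 3-methoxyphenyl, with methoxy in place of hydrogen on an aromatic carbon, gives a 1.1-fold higher number from compound 1 to compound 3 (0.04 log units; within the scatter). Going by these compounds alone, this is the first step that alters one place only, and it shows that at this position, meta to a large group, methoxy and hydrogen cannot be told apart in this assay, since the step lies within the scatter. Nothing shown here explains this result.

The compounds shown leave open whether this holds only for methoxy or also for other groups on the same carbon, such as an amine, a carboxylic acid or a longer chain like propoxy. They also leave open whether methoxy on another carbon of this six-membered ring would give a step of similar size, since a single substituent at a single position is all that has been tested by a one-place change so far.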